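The source may hold more compounds than are shown below. What is called first, only, known or untested is meant among the compounds shown, and "the series" means these compounds.

The series shares one core and varies the groups around it. Compound 1 `Oc1ccc(-c2cc(-c3cccnc3)nc(-c3ccccc3Cl)c2)cc1` carries a pyridin-3-yl group, but in a functional assay on DU-145 cells (Homo sapiens) for cytotoxicity, read by CCK-8 assay and cell counting, with a stated time of 2 days (on this read-out higher numbers stand for weaker inhibition and lower numbers for stronger inhibition), compound 1 is recorded as "not determined" (no result reported), with no result reported. Compound 2 `Oc1ccc(-c2cc(-c3ccccc3)nc(-c3ccccc3Cl)c2)cc1` gives 2800 nM in this assay. Compound 3 `Oc1cccc(-c2cc(-c3ccsc3)nc(-c3ccccc3Cl)c2)c1` gives 1970 nM in this assay. Among the compounds with values here, these two numbers lie within the usual scatter of each other, so compound 3 cannot be set apart from compound 2 on the evidence at hand; it simply stands among the only two numbers available.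

Compound 4 `Oc1ccc(-c2cc(-c3ccsc3)nc(-c3ccccc3Cl)c2)cc1` has not been measured in this assay. It differs from compound 3 by 4-hydroxyphenyl in place of 3-hydroxyphenyl on an aromatic carbon. Compound 2 already carries a 4-hydroxyphenyl group on the same core and gives 2800 nM, a number within the scatter of compound 3, so the same atoms joined differently have not, in this small set, produced a clear shift. For the step from compound 3 to compound 4 in this assay, an estimated change of a 1.2-fold higher number from compound 3 to compound 4 (0.09 log units; within the scatter) is expected, essentially none beyond the scatter. Compound 4 is therefore expected to give about 2400 nM in this assay, within a range from 900 nM to 6500 nM.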

Compound 4, half-maximal inhibitory concentration: 3890 nM
Beside the measured number, compound 4's estimate is 1.6-fold (0.21 log units) below it; low and high end bracket the measured number.
By their numbers in this assay, from the lowest: compounds 3, 2 and 4 (each within the scatter of the next).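

In this assay, within the data shown here, the exchange of 3-hydroxyphenyl for 4-hydroxyphenyl on the aromatic carbon opposite the ring nitrogen gives a 2.0-fold higher number from compound 3 to compound 4 (0.30 log units; within the scatter), the first direct reading of this change on the shared core, and it remains within the scatter. With 4-hydroxyphenyl held in place, thiophen-3-yl in place of phenyl gives a 1.4-fold higher number from compound 2 to compound 4 (0.14 log units; within the scatter), which is also within the scatter, so these two groups cannot be told apart on this read-out. Neither single change therefore separates the compounds it connects, so in this small set neither the placing of the hydroxyl group on the phenyl ring nor the choice between thiophen-3-yl and phenyl has a demonstrated effect on the number.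

No supporting measurement is available that could explain these results. The compounds shown leave open whether a methoxy group or an amine in place of the hydroxyl group, or a carboxylic acid on that phenyl ring, would move the number beyond the scatter, and the pyridin-3-yl group of compound 1 still has no number to compare with phenyl or thiophen-3-yl.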